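Working notes: chlorine position and metabolic stability

The compounds below may be only part of what the source reports. "The series", "measured", "known", "first", "only" and "open" are said of these compounds alone.

Measured compounds:
- compound 1 `O=S(=O)(c1cc(F)cc(F)c1)c1cnc2c(F)cccc2c1-c1cccc(Cl)c1`: 0.64 mL/min
- compound 2 `O=S(=O)(c1cc(Cl)cc(Cl)c1)c1cnc2c(F)cccc2c1-c1cccc(Cl)c1`: 1.2 mL/min
- compound 3 `O=S(=O)(c1ccc(F)cc1)c1cnc2c(F)cccc2c1-c1cccc(Cl)c1`: 1.21 mL/min

All three share one core and differ only in the aryl on the sulfonyl sulfur; each was run in an ADME assay on microsomes from liver (Homo sapiens) for metabolic stability, tested at 2.5 uM; a lower number here means slower removal, a higher number faster removal of the compound. Compound 2 stands with compound 3: the two numbers are the same, a 1.0-fold higher number from compound 2 to compound 3 (0.00 log units; within the scatter). The only separation in the set is a 1.9-fold higher number from compound 1 to compound 2 (0.27 log units; within the scatter) and the matching a 1.9-fold higher number from compound 1 to compound 3 (0.28 log units; within the scatter), both within the scatter. On the numbers shown, the three compounds cannot be told apart in this assay.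

Compound 4 `O=S(=O)(c1cc(Cl)cc(Cl)c1)c1cnc2c(F)cccc2c1-c1ccc(Cl)cc1` is not yet measured. It differs from compound 2 at a different site: 4-chlorophenyl in place of 3-chlorophenyl on an aromatic carbon. Among the measured compounds shown here, none of the measured steps touches this position; all three concern the aryl on the sulfonyl sulfur, and they are small in any case. For the measured compounds named here, there is thus no measured step that bears on the change from compound 2 to compound 4, and no ground for expecting a step beyond the scatter in either direction.

For compound 4 the expected value in this assay is 1.2 mL/min, with a range of 0.6 mL/min to 2.4 mL/min. The step this estimate implies is no change at the digits printed from compound 2 to compound 4 (within the scatter), which is expected to lie within the scatter.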

Compound 4, intrinsic clearance in a liver preparation (reported as CLH), per the amount of preparation that the assay uses: 0.78 mL/min
The estimate for compound 4 lay 1.5-fold (0.19 log units) above the measured number; measured number inside the range.
By their numbers in this assay, from the lowest: compounds 1, 4, 2 and 3 (each within the scatter of the next).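

The chlorophenyl on the shared core now has a measured step of its own: in this assay, with 3,5-dichlorophenyl held constant on the sulfonyl sulfur, 4-chlorophenyl in place of 3-chlorophenyl gives a 1.5-fold lower number from compound 2 to compound 4 (0.19 log units; within the scatter). Among the compounds shown here, the earlier compounds varied only the aryl on the sulfonyl sulfur, so this is the first reading at this site, and for this one pair, shifting the chlorine does not separate the two compounds beyond the scatter. No measurement at hand offers an explanation for the number at this position.

As far as these compounds go, it remains open whether this assay responds at this site to anything larger than a shift of chlorine, such as an amine, a carboxylic acid or a methoxy group on this phenyl, or to the bare phenyl without chlorine. From the compounds shown here alone, it is also open whether 4-chlorophenyl in place of 3-chlorophenyl reads the same with 3,5-difluorophenyl or 4-fluorophenyl on the sulfonyl sulfur, as the present step rests on a single pair.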